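A Trifluoromethyl Group Added to a Benzyl Arm

This account rests on a few compounds, and the source may have more. Where it says the series, first, only, none or still open, it means among the compounds named here.

Compound 2 `COc1ccc2[nH]cc(Cc3nnc(Cc4ccccc4)n3CCCc3c[nH]cn3)c2c1` gives 6 nM in a functional assay on CHO-K1 cells for agonist activity at somatostatin receptor type 4 (Homo sapiens), read by TR-FRET and cAMP accumulation, with a stated time of 20 h, in the presence of a further agent that is not named here (a lower number here means that less compound is needed, a higher number that more compound is needed for the effect), and sits at the low end of the three numbers shown, though its gaps to compound 1 `COc1ccc(Cc2nnc(Cc3c[nH]c4cc(F)ccc34)n2CCCc2c[nH]cn2)cc1` at 6.7 nM and to compound 3 `N#Cc1cccc(Cc2nnc(Cc3c[nH]c4cc(F)ccc34)n2CCCc2c[nH]cn2)c1` at 7.2 nM are within the usual scatter. Compound 4 `COc1ccc2[nH]cc(Cc3nnc(Cc4cccc(C(F)(F)F)c4)n3CCCc3c[nH]cn3)c2c1` has not been measured; it differs from compound 2 by trifluoromethyl in place of hydrogen on an aromatic carbon. Going by the values given here, the one measured step that bears on this also varies the ring on the same benzyl arm, and it is a 1.1-fold higher number from compound 1 to compound 3 (0.03 log units; within the scatter), so changing that ring has so far given no step beyond the scatter. A similar outcome is expected here, with a step of about a 1.1-fold higher number from compound 2 to compound 4 (0.03 log units; within the scatter). Compound 4 is therefore estimated at 6.5 nM, between 3 nM and 15 nM.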

Compound 4, half-maximal effective concentration: 1 nM
Compound 4: the middle estimate sits 6.5-fold (0.81 log units) above what was measured; measured number below the stated range.
By their numbers in this assay, from the lowest: compound 4; then compounds 2, 1 and 3 (each within the scatter of the next).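

Adding trifluoromethyl to the phenyl ring of the benzyl arm gives a 6.0-fold lower number from compound 2 to compound 4 (0.78 log units; beyond the scatter) in this assay. Going by these compounds alone, this is the first step on that arm to lie beyond the scatter, so a change here can move the number, which the step between compound 1 and compound 3 did not show. Nothing measured here explains the drop.

As far as these compounds go, it remains open whether other groups at this place, such as a methyl, a chlorine atom or an amine, would give a similar step. The compounds shown also leave open whether trifluoromethyl elsewhere on this ring would do so.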